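From Furan-2-yl to 2-Chlorophenyl on Compound 2

This account rests on a few compounds, and the source may have more. Where it says the series, first, only, none or still open, it means among the compounds named here.

Cytotoxicity against cancer cells is often the first test of a new compound series, and here the measure is a functional assay on MCF7 cells (Homo sapiens) for cytotoxicity, read by ELISA, with a stated time of 4 days; on this read-out higher numbers stand for weaker inhibition and lower numbers for stronger inhibition. In this test, compound 1 `Cc1ccsc1-c1cc(-c2ccco2)cc(-c2ccccc2Cl)n1` gives 14200 nM, while compound 2 `Clc1ccc(-c2cc(-c3ccoc3)cc(-c3ccco3)n2)s1` gives 4740 nM. Compound 2 therefore holds the lower of the two numbers, and its gap to compound 1 lies beyond the usual scatter.

The next compound to be tested is compound 3 `Clc1ccc(-c2cc(-c3ccoc3)cc(-c3ccccc3Cl)n2)s1`. It is made from compound 2 by one change: 2-chlorophenyl in place of furan-2-yl on an aromatic carbon. For the measured compounds named here, no measured pair shows this exchange on its own, so the forecast rests on thin evidence. Compound 1, which also carries a 2-chlorophenyl group, gives 14200 nM, but it differs from compound 2 in more than one place. That value suggests only a modest loss in this assay, perhaps close to the scatter. The expected step is a 1.5-fold higher number from compound 2 to compound 3 (0.17 log units; within the scatter), toward weaker inhibition. Compound 3 is expected at 7000 nM, with an estimated range from 2500 nM to 20000 nM.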

Compound 3, half-maximal inhibitory concentration: 7360 nM
For compound 3 the middle estimate is 1.1-fold (0.02 log units) below the measured one; measured number inside the range.
By their numbers in this assay, from the lowest: compounds 2, 3 and 1 (each within the scatter of the next, the first and the last beyond it).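

In this assay, for the compounds shown here, putting 2-chlorophenyl in place of furan-2-yl on the aromatic carbon next to the ring nitrogen gives a 1.6-fold higher number from compound 2 to compound 3 (0.19 log units; within the scatter), the first reading of this exchange on its own. The position therefore accepts a six-membered aromatic ring of carbon only, carrying a chlorine, in place of a five-membered aromatic ring with 1 hetero atom, and the number stays within the scatter even though the 1 hydrogen-bond acceptor of furan-2-yl is gone. No measured property of these groups is available to account for this result.

The compounds shown leave open whether the chlorine of the new ring matters, since a plain phenyl group and the 3-chlorophenyl and 4-chlorophenyl groups are not among them, and they do not show how a ring-bearing amine such as morpholine or a carboxylic acid would fare here. They also leave open whether the exchange would read the same with the other two groups on the core changed, as this single step rests on 5-chlorothiophen-2-yl and furan-3-yl alone.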